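Phenyl for tert-butoxy at the assay limit

The source may report more compounds than this note shows. Statements on the series, on what has been measured and on what is new or still open speak of the compounds shown alone.

In a functional assay on Raji cells (Homo sapiens) for cytotoxicity, with a stated time of 72 h (a higher number here means that more compound is needed for the effect, a lower number that less compound is needed), compound 1 `COc1ccc(/C=C/[C@@](C)(/C=C/c2ccc(O)c(C=O)c2)CCC=C(C)C)cc1` gives 13000 nM. Compound 2 `COc1ccc(/C=C/[C@@](C)(/C=C/c2ccc(O)c(/C=C/C#N)c2)CCC=C(C)C)cc1` reads > 26000 nM, which is a limit of the assay and not a number. Compound 3 `COc1ccc(/C=C/[C@@](C)(/C=C/c2ccc(O)c(/C=C/C(=O)OC(C)(C)C)c2)CCC=C(C)C)cc1` reads > 26000 nM, again only a limit. Compound 3 therefore stands at the limit of > 26000 nM in this assay, at which 2 of the 3 values shown sit.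

Compound 4 `COc1ccc(/C=C/[C@@](C)(/C=C/c2ccc(O)c(/C=C/C(=O)c3ccccc3)c2)CCC=C(C)C)cc1` differs from compound 3 by phenyl in place of tert-butoxy on a carbonyl carbon. Going by the values given here, two measured steps bear on this change: an at least 2.0-fold higher number from compound 1 to compound 3 (0.30 log units; that floor lies within the scatter), and a step that the two limits leave unreadable from compound 2 to compound 3. Neither gives a readable size for phenyl in place of tert-butoxy, so no change beyond the scatter is expected. The expected step is an at least 1.1-fold lower number from compound 3 to compound 4 (0.07 log units; that floor lies within the scatter). For compound 4 the estimated value is 22000 nM, with an expected range of 8000 nM to 35000 nM.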

Compound 4, half-maximal effective concentration: > 26000 nM
Compound 4: a limit, no number; the forecaster's own chance of this, stated with the estimate: 60%; at least 1.1-fold (0.07 log units) between middle value and limit.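

Compound 4 is a third compound with an ethenyl chain in place of formyl, and it too gives only a limit of the assay: the limit of > 26000 nM in this assay, at which 3 of the 4 values shown sit. With 2-benzoylethenyl in place of formyl on the aromatic carbon, the record shows an at least 2.0-fold higher number from compound 1 to compound 4 (0.30 log units; that floor lies within the scatter). The steps linking compound 4 to compound 2 and to compound 3 join two limits, so they cannot be read, and phenyl and tert-butoxy cannot be ranked on the carbonyl carbon.

From the compounds shown here alone, how far compounds 2, 3 and 4 lie beyond the limit stays unknown. Also open, going by these compounds, is whether a chain ending in a carboxylic acid or an amine would give a number.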